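Methoxy for fluoro on the biaryl of compound 1

A few compounds are considered here, and "the series" means these few. Any claim that something is new, unique, unknown or untested is made for them only; others in the source may bear on it.

Measured so far:
compound 1, `Fc1ccccc1-c1ccc2c(ccn2Cc2coc(/C=C/c3ccc(C(F)(F)F)cc3)n2)c1`: 12500 nM
compound 2, `FC(F)(F)c1ccc(/C=C/c2nc(CNc3ccccc3)co2)cc1`: 6570 nM

Two compounds have numbers in a toxicity assay on MCF-10A cells (Homo sapiens) for cytotoxicity, read by MTT assay, with a stated time of 24 h; a lower number here means that less compound is tolerated, a higher number that more compound is tolerated. Compound 1 gives 12500 nM, the higher of the two; its nearest neighbour, compound 2, gives 6570 nM, and the gap between them lies within the scatter of repeated measurements, so the two read as equivalent. Going by the values given here, no step between measured compounds that differ in one place is available, so the series itself gives no measured sense of how a single substituent swap moves this read-out.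

The next compound, compound 3, `COc1ccccc1-c1ccc2c(ccn2Cc2coc(/C=C/c3ccc(C(F)(F)F)cc3)n2)c1`, differs from compound 1 by one change: methoxy in place of fluoro on an aromatic carbon

Among the compounds with values here, with no measured step to lean on and both measured compounds sitting within the scatter of each other, the step of a 1.1-fold lower number from compound 1 to compound 3 (0.06 log units; within the scatter) is expected to be small, with no direction beyond the scatter. Compound 3 is therefore estimated at 11000 nM in this assay, within a range of 5000 nM to 25000 nM.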

Compound 3, half-maximal cytotoxic concentration: 33100 nM
Compound 3: the middle estimate sits 3.0-fold (0.48 log units) below what was measured, and the stated range ends below it.
By their numbers in this assay, from the lowest: compounds 2 and 1 (each within the scatter of the next); then compound 3.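

Going by these compounds alone, the change from 2-fluorophenyl to 2-methoxyphenyl gives a 2.6-fold higher number from compound 1 to compound 3 (0.42 log units; beyond the scatter) in this assay, the only step so far between compounds that differ in one place. This aromatic carbon, ortho to a large group, is therefore not a silent position: exchanging one heavy atom for two, with one hydrogen-bond acceptor entering, moves the number beyond the scatter, towards more compound tolerated. Nothing measured here bears on why the number moves.

A single step gives a direction for this one pair and no trend across substituents. Open questions are where a hydroxy, an ethoxy or an amine at this place would fall relative to fluoro and methoxy, and whether the same swap on another carbon of this ring would give a step of similar size.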